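The source may hold more compounds than are shown below. What is called first, only, known or untested is meant among the compounds shown, and "the series" means these compounds.

Compound 2 `COc1ccc(-n2c(=O)n(Cc3cc4cc(Cl)ccc4n3CCCC#N)c3cnccc32)cc1OC` was tested in an ADME assay on HeLa cells (Homo sapiens) for cytotoxicity, read by ATP content, with a stated time of 3 days; a higher number here means that more compound is tolerated, a lower number that less compound is tolerated. In this assay compound 2 gives > 50000 nM, which is a limit of the assay rather than a number. Compound 1 `CS(=O)(=O)CCCn1c(Cn2c(=O)n(CC#N)c3ccncc32)cc2cc(Cl)ccc21` likewise gives only a limit, > 50000 nM. Compound 3 `CC(C)CCn1c(Cn2c(=O)n(C3CC3)c3ccncc32)nc2ncccc21` also gives a limit, > 100000 nM. Compound 2 therefore stands among values that are all limits: the limit of > 50000 nM in this assay, at which 2 of the 3 values shown sit, and (the limit of > 100000 nM in this assay, at which 1 of the 3 values shown sits). Compound 4 `COc1ccc(-n2c(=O)n(Cc3cc4cc(Cl)ccc4n3CCCC#N)c3cnccc32)c(C)c1` differs from compound 2 by 4-methoxy-2-methylphenyl in place of 3,4-dimethoxyphenyl on an aromatic nitrogen. For the measured compounds named here, no measured step between two compounds is available here. In this assay the change is expected to give no step beyond the scatter. Compound 4 is estimated at 60000 nM, between 30000 nM and 200000 nM. That expectation means a step that the limit leaves unreadable from compound 2 to compound 4.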

Compound 4, half-maximal cytotoxic concentration: > 50000 nM
Compound 4 was reported as a limit; the forecaster's own chance of this, stated with the estimate: 85%; the middle value does not contradict the limit.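

For the compounds shown here, compound 2 and compound 4 both give only limits in this assay, so no step between them can be read. The compounds shown leave open the concentration at which any of them becomes toxic to the cells, and whether 4-methoxy-2-methylphenyl in place of 3,4-dimethoxyphenyl changes it.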